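This account rests on a few compounds, and the source may have more. Where it says the series, first, only, none or still open, it means among the compounds named here.

Measured in a functional assay on HL-60 cells (Homo sapiens) for antiproliferative activity; on this read-out lower numbers stand for stronger inhibition and higher numbers for weaker inhibition:
- compound 1 `CCOC(=O)c1ccc(Oc2ccc(OC)c(OC)c2)cc1O`: 1500 nM
- compound 2 `CCOC(=O)c1ccc(Oc2ccc(F)c(F)c2)cc1O`: > 30000 nM (a limit)
- compound 3 `COC(=O)c1ccc(Oc2ccc(OC)c(OC)c2)c([N+](=O)[O-])c1`: > 20000 nM (a limit)

Only compound 1 has a true number in this small set. Compound 2 gives > 30000 nM, which is a limit of the assay and not a number. From the compounds shown here alone, compound 3 gives > 20000 nM, which is likewise only a limit, so its exact place on the scale is unknown.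

The next compound, compound 4 `COC(=O)c1ccc(Oc2ccc(OC)c(OC)c2)c(N)c1`, has amino in place of nitro on an aromatic carbon, ortho to a large group and meta to a methoxycarbonyl group: amino in place of nitro on an aromatic carbon. Going by the values given here, no pair of measured compounds differs by this change or by any other single change, so the size of the step in this assay has to be judged with little support. Compound 1 gives 1500 nM, so a measurable value is possible among these close relatives, and a moderate move toward stronger inhibition seems reasonable. There is also a real chance that compound 4 will return only a limit. The estimated change is an at least 2.0-fold lower number from compound 3 to compound 4 (0.30 log units; that floor lies within the scatter), and it is uncertain because compound 3 has only the limit > 20000 nM as its starting point. For compound 4 the expected value is 10000 nM, with an estimated range of 2500 nM to 40000 nM.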

Compound 4, half-maximal inhibitory concentration: > 20000 nM
Compound 4 ended at the assay's limit; the forecaster's own chance of this, stated with the estimate: 40%; at least 2.0-fold (0.30 log units) between middle value and limit.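

In this assay, compound 3 and compound 4 both sit at a limit of the assay and not at a true number, so no step from one to the other can be read: the limit of > 20000 nM in this assay, at which 2 of the 4 values shown sit.

The compounds shown leave open how strongly either compound inhibits, and whether amino in place of nitro changes the read-out at all.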